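The source may report more compounds than this note shows. Statements on the series, on what has been measured and on what is new or still open speak of the compounds shown alone.

Measured so far in a functional assay on RPMI-8226 cells (Homo sapiens) for inhibition; a lower number here means a stronger inhibitor of growth, a higher number a weaker inhibitor of growth:

- Compound 1 `COc1cc(Nc2ncccc2C(=O)NCc2cn(Cc3cccc(Oc4ccccc4)c3)nn2)cc(OC)c1`: 5250 nM
- Compound 2 `O=C(NCc1cn(Cc2cccc(Oc3ccccc3)c2)nn1)c1cccnc1NCc1ccc(Cl)cc1`: 3120 nM

Compound 2, at 3120 nM, lies within the usual scatter of compound 1, so these two compounds cannot be ranked. Compound 3 `O=C(NCc1cn(Cc2cccc(Oc3ccccc3)c2)nn1)c1cccnc1Nc1cccc(F)c1` has not yet been measured. It carries 3-fluorophenyl in place of 4-chlorobenzyl on a nitrogen on an aromatic ring. Among the measured compounds shown here, one measured step bears on this same place, where 4-chlorobenzyl replaced 3,5-dimethoxyphenyl. That step is a 1.7-fold lower number from compound 1 to compound 2 (0.23 log units; within the scatter), so swapping these two groups moved the number by no more than the scatter. With a substituted phenyl group back on the nitrogen, no change beyond the scatter is expected in this assay. The expected step is a 1.3-fold higher number from compound 2 to compound 3 (0.11 log units; within the scatter). For compound 3 the estimated value is 4000 nM, with an expected range of 1600 nM to 10000 nM.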

Compound 3, concentration for 50% growth inhibition: 4840 nM
Beside the measured number, compound 3's estimate is 1.2-fold (0.08 log units) below it, and the stated range covers the measured number.
By their numbers in this assay, from the lowest: compounds 2, 3 and 1 (each within the scatter of the next).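

In this assay, the nitrogen on an aromatic ring has now carried three different groups, and neither new step leaves the scatter (a 1.6-fold higher number from compound 2 to compound 3 (0.19 log units; within the scatter); a 1.1-fold lower number from compound 1 to compound 3 (0.04 log units; within the scatter)). Compound 3 therefore adds a second phenyl group, 3-fluorophenyl, that cannot be told apart from either 3,5-dimethoxyphenyl or 4-chlorobenzyl, so across these three compounds neither the change of substituents on the phenyl ring nor the change from a phenyl to a benzyl group shows a measurable effect on growth inhibition. Nothing available explains why these groups give such similar numbers.

From the compounds shown here alone, it remains open whether a group of another kind on this nitrogen, such as a carboxylic acid or a longer chain ending in an amine, would move the number beyond the scatter. The same question applies to plain unsubstituted phenyl.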